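The source may report more compounds than this note shows. Statements on the series, on what has been measured and on what is new or still open speak of the compounds shown alone.

Compound 1 `COc1c(Br)cc(Br)cc1C(=O)Nc1ccccc1` — in an assay on isolated protein for inhibition of thiosulfate sulfurtransferase (Homo sapiens), with a stated time of 60 min, in the absence of a further agent (on this read-out lower numbers stand for stronger inhibition and higher numbers for weaker inhibition), compound 1 gives > 100000 nM, which is a limit of the assay.
Compound 2 `COc1c(Br)cc(Br)cc1C(=O)Nc1ccc(Sc2nc3ccccc3s2)cc1` — in this assay compound 2 gives > 100000 nM, again a limit of the assay.
Compound 3 `COc1c(Br)cc(Br)cc1C(=O)Nc1ccc(Sc2nc3ccccc3s2)c(Cl)c1` — in this assay compound 3 gives > 100000 nM, also a limit of the assay.

On the numbers shown, compound 2 therefore stands at a limit and not at a number, and so do the other two measured compounds; the whole of the evidence is the limit of > 100000 nM in this assay, at which 3 of the 3 values shown sit. For the measured compounds named here, the single measured step between compounds differing in one place, a step that the two limits leave unreadable from compound 2 to compound 3, runs from one limit to another, and its size cannot be read.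

Compound 4 `COc1c(Br)cccc1C(=O)Nc1ccc(Sc2nc3ccccc3s2)cc1` differs from compound 2 by hydrogen in place of bromo on an aromatic carbon. Going by the values given here, no measured step touches this change, and the one step that exists on the shared core is itself unreadable. The inhibition figures of the measured compounds give no ground to expect a step beyond the scatter in this assay in either direction. The step to compound 4 is accordingly expected to be a step that the limit leaves unreadable from compound 2 to compound 4. Compound 4 is estimated to give 150000 nM, within 50000 nM to 500000 nM, and most probably the assay will again report only a limit.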

Compound 4, half-maximal inhibitory concentration: > 100000 nM
Compound 4: no number, only a limit; the forecaster's own chance of this, stated with the estimate: 85%; the middle value does not contradict the limit.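

Compound 4, like compound 2, stands at a limit of the assay and not at a number, so the step between compound 2 and compound 4 cannot be read in this assay. The compounds shown leave open whether any of them inhibits the enzyme measurably, and how much hydrogen in place of bromo changes inhibition on the shared core.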